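A few compounds are considered here, and "the series" means these few. Any claim that something is new, unique, unknown or untested is made for them only; others in the source may bear on it.

Measured so far in a functional assay on MDA-MB-231 cells (Homo sapiens) for antiproliferative activity, read by MTT assay; on this read-out higher numbers stand for weaker inhibition and lower numbers for stronger inhibition:
Compound 1 `Oc1nc(-c2ccc(F)cc2)nc2ccccc12` gives 20000 nM
Compound 2 `O=c1[nH]c(-c2cccc(Cl)c2)nc2ccccc12` gives 41000 nM
Compound 3 `CCCc1nn(C)c2c(=O)[nH]c(-c3ccc(Br)cc3)nc12` gives 46000 nM

Compound 3 (46000 nM) lies within the usual scatter of compound 2 (41000 nM), so that pair cannot be told apart. Against compound 1 (20000 nM) the gap is beyond the scatter, and compound 3 is the less potent of those two.

The next compound, compound 4 `CCCc1nn(C)c2c(=O)[nH]c(-c3ccc(C)cc3)nc12`, differs from compound 3 in one place: 4-bromophenyl becomes 4-methylphenyl, with methyl in place of bromo on an aromatic carbon, para to a large group. The change is counted as methyl in place of bromo on an aromatic carbon in this swap. For the measured compounds named here, no measured pair isolates this change, so the data do not show directly how this assay responds to it. The widest gap among the measured compounds, between compound 3 and compound 1, is only just beyond the scatter, and this offers little ground for expecting a large move. The estimated 1.2-fold lower number from compound 3 to compound 4 (0.06 log units; within the scatter) stays within the scatter, and no firm direction is expected. In this assay compound 4 is expected at 40000 nM, with an estimated span from 18000 nM to 85000 nM as the likely range.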

Compound 4, half-maximal inhibitory concentration: 48000 nM
For compound 4 the middle estimate is 1.2-fold (0.08 log units) below the measured one, and the stated range covers the measured number.
By their numbers in this assay, from the lowest: compound 1; then compounds 2, 3 and 4 (each within the scatter of the next).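

In this assay, for the compounds shown here, the exchange of bromo for methyl on an aromatic carbon of the six-membered ring, para to a large group, provides the first step in this set that isolates a single change: a 1.0-fold higher number from compound 3 to compound 4 (0.02 log units; within the scatter). Going by these compounds alone, at this position, therefore, bromo and methyl cannot be told apart on this read-out, something the earlier compounds could not show, since none of them formed a pair differing in only one place. No supporting information bearing on this result is available, so the step stands as an observation without an explanation.

The compounds shown pair only these two substituents at this position, so they leave open whether a more different group here, such as an amine or a carboxylic acid, would produce a step beyond the scatter. They also leave open how a longer chain in place of the propyl group on the shared core would read, and whether the gap separating compound 1 from compound 3 can be traced to any single structural difference.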